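The compounds below may be only part of what the source reports. "The series", "measured", "known", "first", "only" and "open" are said of these compounds alone.

Of the compounds shown here, three have been measured in a functional assay on a cell-free system (Platelet, plasma, Oryctolagus cuniculus) for inhibition, with a stated time of 5 min; a lower number here means a stronger inhibitor, a higher number a weaker inhibitor. Compound 1 `CCOC(=O)/C=C/c1cccc(OCc2nc(C)c(C)nc2C)c1` gives 628000 nM. Compound 3 `Cc1nc(C)c(COc2cccc(/C=C/C(=O)O)c2)nc1C` gives 161000 nM. The change between them, (hydrogen in place of ethyl on an oxygen next to a carbonyl group), produced a 3.9-fold lower number from compound 1 to compound 3 (0.59 log units; beyond the scatter). Compound 2 `CCOC(=O)/C=C/c1cc(Br)cc(Br)c1OCc1nc(C)c(C)nc1C` reaches only a limit in this assay, > 2000000 nM, namely (the limit of > 2000000 nM in this assay, at which 1 of the 3 values shown sits). The difference between the core of compound 1 and the core of compound 2 is not broken down here.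

Compound 4 `Cc1nc(C)c(COc2c(Br)cc(Br)cc2/C=C/C(=O)O)nc1C` is not yet measured in this assay. It differs from compound 2 by hydrogen in place of ethyl on an oxygen next to a carbonyl group, the same change as from compound 1 to compound 3. The step from compound 2 to compound 4 is expected to be about an at least 1.3-fold lower number from compound 2 to compound 4 (0.12 log units; that floor lies within the scatter), resting on a 3.9-fold lower number from compound 1 to compound 3 (0.59 log units; beyond the scatter). Since compound 2 gives only a limit, the starting point is itself uncertain, so the estimate is wide. Compound 4 is estimated at 1500000 nM, expected between 400000 nM and 5000000 nM.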

Compound 4, half-maximal inhibitory concentration: 1310000 nM
Compound 4: the middle estimate sits 1.1-fold (0.06 log units) above what was measured; low and high end bracket the measured number.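

Carried to a second core in this assay, the change from ethoxycarbonyl to carboxy gives an at least 1.5-fold lower number from compound 2 to compound 4 (0.18 log units; that floor lies within the scatter). This fits the change carrying over in the same direction, but that floor alone establishes no firm step, and the size of the effect cannot be compared between the two cores: the same change on two cores in this assay, a 3.9-fold lower number (0.59 log units; beyond the scatter) from compound 1 to compound 3 and an at least 1.5-fold lower number (0.18 log units; that floor lies within the scatter) from compound 2 to compound 4; the limit leaves it open whether they differ

The starting point on this core is a limit of the assay, not a number: the limit of > 2000000 nM in this assay, at which 1 of the 4 values shown sits.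

Open is how an amide in place of the ester, or a chain longer than ethyl on that oxygen, would compare with the ethyl esters and carboxylic acids shown. Also open, going by these compounds, is how a core carrying a single bromine would respond to the same change.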